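From 2,5-dimethylphenyl to 4-methoxyphenyl in compound 3

The compounds below may be only part of what the source reports. "The series", "measured", "known", "first", "only" and "open" are said of these compounds alone.

Measured in a functional assay on DU-145 cells (Homo sapiens) for inhibition, read by trypan blue exclusion, with a stated time of 96 h; on this read-out lower numbers stand for stronger inhibition of growth and higher numbers for weaker inhibition of growth:
- compound 1 `O=C(/C(=C\c1ccc(OCc2ccccc2)cc1)SCc1ccc(Cl)cc1)c1ccc(Cl)cc1`: 1000 nM
- compound 2 `Cc1ccc(C)c(/C=C(/SCc2ccc(Cl)cc2)C(=O)c2ccc(Cl)cc2)c1`: 10000 nM

Of these two numbers, compound 2 has the higher, at 10000 nM, and the gap down to compound 1 lies beyond the scatter.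

Compound 3 `COc1ccc(/C=C(/SCc2ccc(Cl)cc2)C(=O)c2ccc(Cl)cc2)cc1` has not yet been measured. It differs from compound 2 by one change: 4-methoxyphenyl in place of 2,5-dimethylphenyl on a double-bonded chain carbon bound to a double-bonded chain carbon, with 4-methoxyphenyl in place of 2,5-dimethylphenyl on a double-bonded chain carbon bound to a double-bonded chain carbon.

Compound 3 shares an ether oxygen in this part of the structure with compound 1, which gives 1000 nM, so a number closer to that one is expected, although two compounds are thin support. In this assay the expected step is a 3.3-fold lower number from compound 2 to compound 3 (0.52 log units; beyond the scatter), towards stronger inhibition of growth and beyond the scatter. For compound 3 the estimate is 3000 nM, with an expected range from 800 nM to 10000 nM.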

Compound 3, concentration for 50% growth inhibition: 10000 nM
Compound 3: the middle estimate sits 3.3-fold (0.52 log units) below what was measured; low and high end bracket the measured number.
By their numbers in this assay, from the lowest: compound 1; then compounds 2 and 3 (each within the scatter of the next).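

In this assay, 4-methoxyphenyl in place of 2,5-dimethylphenyl on a double-bonded chain carbon bound to a double-bonded chain carbon gives no change at the digits printed from compound 2 to compound 3 (within the scatter), so adding an ether oxygen and a hydrogen-bond acceptor at this place does not by itself bring the number towards that of compound 1. The two ether compounds part at the outer phenyl: hydrogen in place of phenyl on a saturated chain carbon bound to an oxygen on an aromatic ring gives a 10-fold higher number from compound 1 to compound 3 (1.00 log units; beyond the scatter), which ties the stronger inhibition of growth of compound 1 to that phenyl in this single pair. Nothing shown here gives a reason for either step.

Whether the phenyl must be an aromatic ring stays open, since the compounds shown do not include a cyclohexyl or a pyridyl group at that place. A shorter link, such as a phenoxy group directly on the ring, is equally untested among them.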